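Swapping the group on the sulfonyl sulfur of compound 3

This account rests on a few compounds, and the source may have more. Where it says the series, first, only, none or still open, it means among the compounds named here.

Of the compounds shown here, three with a shared core have been measured in an ADME assay on microsomes from liver (Homo sapiens) for pharmacokinetics, read by LC-MS, with a stated time of 60 min, tested at 1 uM; on this read-out lower numbers stand for slow clearance and higher numbers for fast clearance. Compound 1 `CC(C)n1cc(S(=O)(=O)c2ccc(CNC(=O)N3Cc4ccncc4C3)cc2)cn1` gives 4 mL/min/kg, compound 2 `O=C(NCc1ccc(S(=O)(=O)C2CCC(F)(F)CC2)cc1)N1Cc2ccncc2C1` gives 6 mL/min/kg, and compound 3 `CCC(=O)N1CCC(S(=O)(=O)c2ccc(CNC(=O)N3Cc4ccncc4C3)cc2)CC1` gives 11 mL/min/kg. Compound 3 stands apart from compound 1 alone, with a 2.8-fold higher number from compound 1 to compound 3 (0.44 log units; beyond the scatter). It cannot be told apart from compound 2, with a 1.8-fold higher number from compound 2 to compound 3 (0.26 log units; within the scatter), and the remaining pair shows a 1.5-fold higher number from compound 1 to compound 2 (0.18 log units; within the scatter).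

Compound 4 `O=C(NCc1ccc(S(=O)(=O)N2CCC(N3CCCC3)CC2)cc1)N1Cc2ccncc2C1` changes the same place, with 4-(pyrrolidin-1-yl)piperidin-1-yl in place of 1-propanoylpiperidin-4-yl on a sulfonyl sulfur. Among the measured compounds shown here, all three measured steps exchange the group at this place, and only the one from compound 1 to compound 3 goes beyond the scatter, and then only modestly. For the measured compounds named here, none of the measured compounds carries the incoming group, so the direction stays open, and no step beyond the scatter is expected in this assay. The expected change is a 1.1-fold lower number from compound 3 to compound 4 (0.04 log units; within the scatter). For compound 4 the estimated clearance is 10 mL/min/kg, with an expected range from 4 mL/min/kg to 25 mL/min/kg.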

Compound 4, clearance: 6 mL/min/kg
Compound 4: middle estimate off by 1.7-fold (0.22 log units), on the high side, within the range that was stated.
By their numbers in this assay, from the lowest: compounds 1, 2, 4 and 3 (each within the scatter of the next, the first and the last beyond it).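

In this assay the group 4-(pyrrolidin-1-yl)piperidin-1-yl on the sulfonyl sulfur cannot be told apart from any of the three earlier groups: the steps read (a 1.8-fold lower number from compound 3 to compound 4 (0.26 log units; within the scatter)), (no change at the digits printed from compound 2 to compound 4 (within the scatter)) and (a 1.5-fold higher number from compound 1 to compound 4 (0.18 log units; within the scatter)). Among the compounds shown here, a group with both a five-membered and a six-membered non-aromatic ring can therefore sit at this place and still land inside the span set by compound 1 and compound 3, the only pair still lying beyond the scatter of each other. No measurement at hand explains these numbers.

A plain piperidin-1-yl or a morpholine on the sulfonyl sulfur would show whether the pyrrolidine part of the new group matters to this read-out at all. From the compounds shown here alone, whether any group here can move clearance outside that span also stays open.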